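A few compounds are considered here, and "the series" means these few. Any claim that something is new, unique, unknown or untested is made for them only; others in the source may bear on it.

Of the compounds shown here, three sharing one core have been measured in a functional assay on DU-145 cells (Homo sapiens) for cytotoxicity, read by MTT assay; a higher number here means a weaker inhibitor, a lower number a stronger inhibitor. Compound 1 (`CC(C)=CC[C@@H](OC(=O)CCO)C1=CC(=O)c2c(O)ccc(O)c2C1=O`) gives 55300 nM and compound 2 (`CCCCC(O)CC(=O)O[C@H](CC=C(C)C)C1=CC(=O)c2c(O)ccc(O)c2C1=O`) gives 45300 nM, two values within the scatter of each other. Compound 3 (`CCC(C)(O)CC(=O)O[C@H](CC=C(C)C)C1=CC(=O)c2c(O)ccc(O)c2C1=O`) gives 16000 nM, the lowest number of the three, which makes it the strongest inhibitor so far.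

Compound 4 (`CCC(CO[C@H](CC=C(C)C)C1=CC(=O)c2c(O)ccc(O)c2C1=O)OC`) differs from compound 3 in one place: 2-methoxybutyl in place of (2-hydroxy-2-methylbutyl)carbonyl on an oxygen on a saturated carbon. Put simply, 2-methoxybutyl stands in place of (2-hydroxy-2-methylbutyl)carbonyl on an oxygen on a saturated carbon. Within the data shown here, no measured step makes this change, since compounds 1, 2 and 3 all keep the carbonyl and differ only further along the chain. The nearest guides are therefore indirect. The step of a 1.2-fold lower number from compound 1 to compound 2 (0.09 log units; within the scatter) stays within the scatter, while a 3.5-fold lower number from compound 1 to compound 3 (0.54 log units; beyond the scatter) and a 2.8-fold lower number from compound 2 to compound 3 (0.45 log units; beyond the scatter) are modest. Changes to this chain have so far moved this assay only slightly, though the loss of the carbonyl is untested and the data do not settle a direction. The expected result is a 1.1-fold lower number from compound 3 to compound 4 (0.06 log units; within the scatter), an estimated shift within the scatter. Compound 4 is estimated at 14000 nM, with an expected range from 4000 nM to 45000 nM.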

Compound 4, half-maximal inhibitory concentration: 45700 nM
For compound 4 the middle estimate is 3.3-fold (0.51 log units) below the measured one; the whole stated range lies below it.
By their numbers in this assay, from the lowest: compound 3; then compounds 2, 4 and 1 (each within the scatter of the next).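

Among these compounds, replacing (2-hydroxy-2-methylbutyl)carbonyl with 2-methoxybutyl on an oxygen on a saturated carbon removes the carbonyl at this position, unlike the changes among the earlier compounds, and in this assay it gives a 2.9-fold higher number from compound 3 to compound 4 (0.46 log units; beyond the scatter), a modest step that takes away the lead compound 3 held over the other compounds. Against the other two compounds, the same position reads a 1.0-fold higher number from compound 2 to compound 4 (0.00 log units; within the scatter) and a 1.2-fold lower number from compound 1 to compound 4 (0.08 log units; within the scatter), both within the scatter, so a chain without the carbonyl falls in with compounds 1 and 2 and compound 3 alone stands apart. Nothing in the data at hand accounts for this result.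

The swap changes the carbonyl and the hydroxy group together, with the one hydrogen-bond donor leaving and none entering, so the compounds shown do not separate which part of it goes with the step away from compound 3. On these data alone, how a chain ending in an amine or a carboxylic acid at this position would read in this assay also stays open.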